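Adding methyl to a saturated ring carbon of compound 1

This account rests on a few compounds, and the source may have more. Where it says the series, first, only, none or still open, it means among the compounds named here.

In a functional assay for inhibition, with Homo sapiens as the target (on this read-out lower numbers stand for an effect already at smaller amounts and higher numbers for an effect only at larger amounts of compound), compound 1 `Nc1ccc(C2=NNC(=O)CC2)cc1` gives 46.4 ug/mL, the higher of the two exact numbers available. Compound 2 `CCC(=O)Nc1ccc(C2=NNC(=O)CC2)cc1` gives 0.64 ug/mL. Compound 3 `CN1N=C(c2ccc(N)cc2)CCC1=O` reads > 46.4 ug/mL, which is a limit of the assay and not a number.

Compound 4 `CC1CC(c2ccc(N)cc2)=NNC1=O` has not been measured yet. It departs from compound 1 by a single change, (methyl in place of hydrogen on a saturated ring carbon). Two measured steps offer guidance, though neither is made at this place. Propanoyl in place of hydrogen on a nitrogen on an aromatic ring gave a large change, a 73-fold lower number from compound 1 to compound 2 (1.86 log units; beyond the scatter). Methyl in place of hydrogen on an amide-type nitrogen in a ring is the closer comparison, since the same group enters, and it gave a number no lower from compound 1 to compound 3 (the limit leaves the size open). Going by the values given here, with no measured step at a saturated ring carbon, no step beyond the scatter is expected in either direction. The expected step is a 1.3-fold lower number from compound 1 to compound 4 (0.12 log units; within the scatter). For compound 4 the estimated value is 35 ug/mL, with an expected range from 8 ug/mL to 100 ug/mL.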

Compound 4, half-maximal effective concentration: 43.8 ug/mL
Beside the measured number, compound 4's estimate is 1.3-fold (0.10 log units) below it, and the stated range covers the measured number.
By their numbers in this assay, from the lowest: compound 2; then compounds 4 and 1 (each within the scatter of the next).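

In this assay, methyl in place of hydrogen on a saturated ring carbon gives a number that cannot be told apart from that of the parent, with a 1.1-fold lower number from compound 1 to compound 4 (0.03 log units; within the scatter). Going by these compounds alone, this is the first exact reading of a methyl group added to the core of compound 1, and it shows that this ring carbon can carry the group with the number staying within the scatter. Compound 3 ends at a limit and not a number, so its step from compound 1 cannot be read: the limit of > 46.4 ug/mL in this assay, at which 1 of the 4 values shown sits.

On these data alone, whether a longer chain, a hydroxyl group or an amine on this saturated ring carbon would also stay within the scatter of compound 1 remains open. Also open, as far as these compounds go, is what methyl at this place would do on compound 2, which carries propanoyl on the aromatic amine nitrogen and gives 0.64 ug/mL.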